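The source may report more compounds than this note shows. Statements on the series, on what has been measured and on what is new or still open speak of the compounds shown alone.

Working notes on the series. Compound 1 `Oc1cccc(-c2cc(-c3ccncc3)nc(-c3cccc(Cl)c3)c2)c1` has no single number in a functional assay on DU-145 cells (Homo sapiens) for cytotoxicity, read by CCK-8 assay and cell counting, with a stated time of 2 days; a lower number here means a stronger inhibitor, a higher number a weaker inhibitor; its result is recorded as "not determined" (no result reported). Compound 2 `Oc1ccc(-c2cc(-c3ccncc3)nc(-c3cccc(Cl)c3)c2)cc1` is the one further entry without a single number in this assay, recorded as "not determined" (no result reported). Among the compounds with values here, the only measured member is compound 3 `Oc1cccc(-c2cc(-c3ccncc3)nc(-c3ccc(Cl)cc3)c2)c1`, which gives 2510 nM in this assay. Compound 4 `Oc1cccc(-c2cc(-c3ccccc3)nc(-c3cccc(Cl)c3)c2)c1` is not yet measured. The change from compound 1 to compound 4 is phenyl in place of pyridin-4-yl on an aromatic carbon of the shared core. Within the data shown here, no step between measured compounds is known for this series, so the direction cannot be read from the data; a modest shift in this assay, of either sign, is expected rather than a large one. For compound 4 the estimate in this assay is 5000 nM, within a range of 1000 nM to 30000 nM.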

Compound 4, half-maximal inhibitory concentration: 2750 nM
The estimate for compound 4 lay 1.8-fold (0.26 log units) above the measured number; low and high end bracket the measured number.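

In this assay, within the data shown here, compound 1 carries no single number, so no step from it to compound 4 can be read. The compounds shown leave open what phenyl in place of pyridin-4-yl does on the shared core. No evidence bears on this result.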